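Cytotoxicity in the shared series: carbamate for acetate

A few compounds are considered here, and "the series" means these few. Any claim that something is new, unique, unknown or untested is made for them only; others in the source may bear on it.

Three compounds of the series have a reading in an ADME assay on TZM cells (Homo sapiens) for cytotoxicity, with a stated time of 1 days; on this read-out higher numbers stand for lower toxicity in this test and lower numbers for higher toxicity in this test. Compound 1 `Cc1cc(CCC#N)cc(C)c1Oc1cc(Nc2ccc(C#N)cc2)c(N)cc1C(=O)NC1CC1` gives 121000 nM. Compound 2 `Cc1cc(CCC#N)cc(C)c1Oc1cc(Nc2ccc(C#N)cc2)c(N)cc1CNC1CC1` gives 25500 nM. Compound 3 `CC(=O)OCc1cc(N)c(Nc2ccc(C#N)cc2)cc1Oc1c(C)cc(CCC#N)cc1C` gives 44800 nM, which stands second highest among the measured compounds; its step to compound 2, a 1.8-fold higher number from compound 2 to compound 3 (0.24 log units; within the scatter), lies within the scatter, while its step from compound 1, a 2.7-fold lower number from compound 1 to compound 3 (0.43 log units; beyond the scatter), lies beyond it, as does a 4.7-fold lower number from compound 1 to compound 2 (0.68 log units; beyond the scatter).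

Compound 4 `CNC(=O)OCc1cc(N)c(Nc2ccc(C#N)cc2)cc1Oc1c(C)cc(CCC#N)cc1C` differs from compound 3 by methylamino in place of methyl on a carbonyl carbon. Among the compounds with values here, no measured step touches the carbonyl substituent itself; the closest comparison is the exchange at the saturated chain carbon, a 1.8-fold higher number from compound 2 to compound 3 (0.24 log units; within the scatter), which stayed within the scatter, whereas the larger shifts a 4.7-fold lower number from compound 1 to compound 2 (0.68 log units; beyond the scatter) and a 2.7-fold lower number from compound 1 to compound 3 (0.43 log units; beyond the scatter) concern the removal of the cyclopropylcarbamoyl group, a change absent here. The small shift of methyl to methylamino on the carbonyl carbon is therefore expected to move this assay by no more than the scatter, the estimated step being a 1.0-fold higher number from compound 3 to compound 4 (0.00 log units; within the scatter). Compound 4 is thus expected to give 45000 nM, with a range of 18000 nM to 110000 nM.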

Compound 4, half-maximal cytotoxic concentration: 46800 nM
Estimate against measurement, compound 4: 1.0-fold (0.02 log units) below; the range from low to high includes it.
By their numbers in this assay, from the lowest: compounds 2, 3 and 4 (each within the scatter of the next); then compound 1.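

Methylamino in place of methyl on the carbonyl carbon gives the first direct reading at this position in this assay, and the acetate and the carbamate cannot be told apart (a 1.0-fold higher number from compound 3 to compound 4 (0.02 log units; within the scatter)). The carbamate also stays within the scatter of the cyclopropylamino compound (a 1.8-fold higher number from compound 2 to compound 4 (0.26 log units; within the scatter)), while the gap to the cyclopropylcarbamoyl compound remains (a 2.6-fold lower number from compound 1 to compound 4 (0.41 log units; beyond the scatter)), so among these four compounds only the cyclopropylcarbamoyl group sets a reading apart. No measurement at hand bears on the reason for these readings.

On these data alone, whether a longer chain on the carbamate nitrogen, such as ethylamino or cyclopropylamino on the same carbonyl carbon, would also leave the reading within the scatter remains open. Also open, as far as these compounds go, is how a plain hydroxymethyl in place of ((methylcarbamoyl)oxy)methyl on the aromatic carbon would read.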